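Double-bond geometry and cytotoxicity in a stereoisomer series

The source may report more compounds than this note shows. Statements on the series, on what has been measured and on what is new or still open speak of the compounds shown alone.

Measured in an ADME assay on HFF cells (Homo sapiens) for cytotoxicity, read by neutral red uptake; on this read-out higher numbers stand for lower toxicity in this test and lower numbers for higher toxicity in this test:
- compound 1 `Nc1ncnc2c1ncn2/C=C1/C[C@H]1[C@H](O)CO`: 206000 nM
- compound 2 `Nc1ncnc2c1ncn2/C=C1\C[C@@H]1[C@@H](O)CO`: > 300000 nM (a limit of the assay, not a number)

Compound 2 stands only at a limit of this assay, with no number to start from. Compound 3 `Nc1ncnc2c1ncn2/C=C1/C[C@@H]1[C@@H](O)CO` is compared with compound 2 here, and the structural difference is this: the two compounds have the same atoms and bonds and differ only in configuration as drawn: 1 of 3 stereo elements differ; a double bond is drawn E in compound 2 and Z in compound 3. Among the compounds with values here, the one measured step bearing on this is an at least 1.4-fold higher number from compound 1 to compound 2 (0.16 log units; that floor lies within the scatter), and it changes the double bond together with both stereocentres. Since that step shows nothing beyond the scatter, an at least 1.1-fold lower number from compound 2 to compound 3 (0.06 log units; that floor lies within the scatter) is the expected step, with no real change anticipated. For compound 3 the expected value is 260000 nM, with an estimated range of 120000 nM to 500000 nM.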

Compound 3, half-maximal cytotoxic concentration: > 300000 nM
Compound 3: no number, only a limit; the forecaster's own chance of this, stated with the estimate: 55%; middle value at least 1.1-fold (0.06 log units) from the limit.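

In this assay compound 3 stands at a limit of the assay, not a number: > 300000 nM. With the double bond drawn Z in both compounds, the two stereocentres alone give an at least 1.4-fold higher number from compound 1 to compound 3 (0.16 log units; that floor lies within the scatter), so they are now separated from the double bond. The step that changes the double bond alone cannot be read, because both its ends are limits: the limit of > 300000 nM in this assay, at which 2 of the 3 values shown sit.

As far as these compounds go, whether double-bond geometry matters at the stereocentres of compound 1 remains open. So does the read-out with an amine or a carboxylic acid in place of a hydroxyl.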